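Terminal chain variants of the dimethoxy cyclohexenone core

A few compounds are considered here, and "the series" means these few. Any claim that something is new, unique, unknown or untested is made for them only; others in the source may bear on it.

Measured so far:
compound 1 `COC1=C(OC)[C@H](O)[C@H](C/C=C(\C)CC/C=C(\C)C[C@@H]2C[C@@H](C)C(=O)O2)[C@@H](C)C1=O` — 14100 nM
compound 2 `COC1=C(OC)[C@H](O)[C@H](C/C=C(\C)CC/C=C(\C)CCC=C(C)C)[C@@H](C)C1=O` — 5700 nM
compound 3 `COC1=C(OC)[C@H](O)[C@H](C/C=C(\C)CC/C=C(\C)C[C@H](O)C=C(C)C)[C@@H](C)C1=O` — 9600 nM

All three were tested in a functional assay on A549 cells (Homo sapiens) for inhibition, read by sulforhodamine B assay, with a stated time of 48 h; a lower number here means a stronger inhibitor of growth, a higher number a weaker inhibitor of growth. On the three numbers, compound 3 stands second highest; its nearest neighbour is compound 1 at a 1.5-fold lower number from compound 1 to compound 3 (0.17 log units; within the scatter), and the other side is compound 2 at a 1.7-fold higher number from compound 2 to compound 3 (0.23 log units; within the scatter), both within the scatter. Among the measured compounds shown here, the only step that clears the scatter is a 2.5-fold lower number from compound 1 to compound 2 (0.39 log units; beyond the scatter), and it is modest.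

Compound 4 `COC1=C(OC)[C@H](O)[C@H](C/C=C(\C)CC/C=C(\C)CCCC(C)CO)[C@@H](C)C1=O` has not yet been measured in this assay. It differs from compound 3 by 3-(hydroxymethyl)butyl in place of 1-hydroxy-3-methylbut-2-en-1-yl on a saturated chain carbon bound to a double-bonded chain carbon. The chain thus keeps one hydroxy and the same count of heavy atoms, but loses the double bond outside aromatic rings and the defined stereocentre.

For the measured compounds named here, the steps that bear on this are the hydroxy for hydrogen change, a 1.7-fold higher number from compound 2 to compound 3 (0.23 log units; within the scatter), and the larger exchange at the same place, a 1.5-fold lower number from compound 1 to compound 3 (0.17 log units; within the scatter), neither beyond the scatter. Only the ring-opening step, a 2.5-fold lower number from compound 1 to compound 2 (0.39 log units; beyond the scatter), moved the number, and compound 4 keeps no ring either way. Going by the values given here, no step changes a double bond to a saturated chain, so nothing beyond the scatter is expected in this assay from compound 3 to compound 4, with a slight lean toward the lower number of compound 2 as an expected outcome, a 1.2-fold lower number from compound 3 to compound 4 (0.08 log units; within the scatter).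

Compound 4 is therefore estimated at 8000 nM, with a range of 3000 nM to 20000 nM.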

Compound 4, concentration for 50% growth inhibition: 7100 nM
Compound 4: middle estimate off by 1.1-fold (0.05 log units), on the high side, and the stated range covers the measured number.
By their numbers in this assay, from the lowest: compounds 2, 4, 3 and 1 (each within the scatter of the next, the first and the last beyond it).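

In this assay the exchange to 3-(hydroxymethyl)butyl gives a 1.4-fold lower number from compound 3 to compound 4 (0.13 log units; within the scatter) even though the double bond and the defined stereocentre of 1-hydroxy-3-methylbut-2-en-1-yl both leave, so among the compounds shown neither feature is needed to keep the number where it stands. Read as 2-(hydroxymethyl)propyl in place of 2-methylprop-1-en-1-yl, the change gives a 1.2-fold higher number from compound 2 to compound 4 (0.10 log units; within the scatter) and also stays within the scatter, which makes the three open chains one group in this assay. Against the ring-bearing chain, the new compound gives a 2.0-fold lower number from compound 1 to compound 4 (0.30 log units; within the scatter) and that too is printed within the scatter, whereas a 2.5-fold lower number from compound 1 to compound 2 (0.39 log units; beyond the scatter) lies beyond it, so only the chain of compound 2 stands clear of the ring-bearing chain.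

On these data alone, whether an amine or a carboxylic acid in place of the hydroxy, or a longer chain at this place, would move the number beyond the scatter stays open. Whether the hydroxy matters at all in a chain without the double bond also stays open, as the saturated chain appears here only with a hydroxy, and nothing at hand gives a measured reason for any of these numbers.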